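A few compounds are considered here, and "the series" means these few. Any claim that something is new, unique, unknown or untested is made for them only; others in the source may bear on it.

Compound 1 `Cc1ccc(NC(=O)c2cccc(/C=C3\CC(=O)N(c4ccccc4)C3=O)c2)cc1` in an ADME assay on HCT-116 cells (Homo sapiens) for cytotoxicity, read by MTT assay, with a stated time of 72 h (on this read-out higher numbers stand for weaker inhibition and lower numbers for stronger inhibition), gives > 100000 nM, which is a limit of the assay rather than a number. Compound 2 `O=C(Nc1ccc(OC(F)F)cc1)c1cccc(/C=C2\CC(=O)N(c3ccccc3)C2=O)c1` in this assay gives > 100000 nM, likewise a limit. Compound 3 `COc1ccc(NC(=O)c2cccc(/C=C3\CC(=O)N(c4ccccc4)C3=O)c2)cc1` in this assay gives > 100000 nM, again a limit.

Compound 3 therefore stands where every measured compound stands, at the limit of > 100000 nM in this assay, at which 3 of the 3 values shown sit, so nothing places it above or below the other two. The unmeasured compound 4 `CSc1cccc(NC(=O)c2cccc(/C=C3\CC(=O)N(c4ccccc4)C3=O)c2)c1` differs from compound 3 in one place: 3-(methylsulfanyl)phenyl in place of 4-methoxyphenyl on an amide-type nitrogen. Three measured steps exist among the measured compounds, a step that the two limits leave unreadable from compound 1 to compound 2, a step that the two limits leave unreadable from compound 1 to compound 3 and a step that the two limits leave unreadable from compound 2 to compound 3, and none of them can be read in size because both of their ends sit at the limit of > 100000 nM in this assay, at which 3 of the 3 values shown sit. Each of those steps alters the same aromatic ring that the change to compound 4 alters, and none of them moved a value off the limit. The expectation for compound 4 is thus again a limit, with an expected step of a number no higher from compound 3 to compound 4 (the limit leaves the size open). The estimate for compound 4 is 100000 nM, expected to fall between 40000 nM and 300000 nM.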

Compound 4, half-maximal inhibitory concentration: 65200 nM
Compound 4: middle estimate off by 1.5-fold (0.19 log units), on the high side, and the stated range covers the measured number.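

In this assay, compound 4 is the only compound shown with a measured number rather than a limit, while the others remain at that limit: the limit of > 100000 nM in this assay, at which 3 of the 4 values shown sit. For the compounds shown here, this gives the first readable steps, an at least 1.5-fold lower number from compound 3 to compound 4 (0.18 log units; that floor lies within the scatter), an at least 1.5-fold lower number from compound 2 to compound 4 (0.18 log units; that floor lies within the scatter) and an at least 1.5-fold lower number from compound 1 to compound 4 (0.18 log units; that floor lies within the scatter), whereas the steps among compound 1, compound 2 and compound 3 cannot be read. Each floor lies within the usual scatter, so swapping the group on the amide-type nitrogen yields a measurable value here without establishing a clear separation from the other compounds.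

Going from 4-methoxyphenyl to 3-(methylsulfanyl)phenyl alters both the atom and the ring position named, and the compounds shown cannot separate those two changes. On these data alone, how an amine or a carboxylic acid on this ring would read also remains open.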